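A few compounds are considered here, and "the series" means these few. Any claim that something is new, unique, unknown or untested is made for them only; others in the source may bear on it.

Working notes on the series. In a toxicity assay on L02 cells (Homo sapiens) for cytotoxicity, read by MTT assay, with a stated time of 72 h (on this read-out lower numbers stand for stronger inhibition and higher numbers for weaker inhibition), compound 1 `O=C1c2c[n+]([O-])c3ccccc3c2C(=O)c2c1c1ccccc1n2Cc1cn([C@H]2O[C@H](CO)[C@@H](O)[C@H]2O)nn1` gives 950 nM, compound 2 `O=C1c2c[n+]([O-])c3ccccc3c2C(=O)c2c1c1ccccc1n2Cc1cn(C[C@H](O)CO)nn1` gives 1130 nM and compound 3 `O=C1c2c[n+]([O-])c3ccccc3c2C(=O)c2c1c1ccccc1n2Cc1cn(CC(O)CO)nn1` gives 1070 nM. Compound 3 thus stands level with the other two within the scatter. All three measured steps are small: a 1.2-fold higher number from compound 1 to compound 2 (0.08 log units; within the scatter), a 1.1-fold higher number from compound 1 to compound 3 (0.05 log units; within the scatter) and a 1.1-fold lower number from compound 2 to compound 3 (0.02 log units; within the scatter). Neither replacing 3,4-dihydroxy-5-(hydroxymethyl)oxolan-2-yl with 2,3-dihydroxypropyl nor leaving the configuration undrawn at the saturated chain carbon moves the number beyond the scatter.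

Next comes compound 4 `CC1(C)OC[C@H](Cn2cc(Cn3c4c(c5ccccc53)C(=O)c3c[n+]([O-])c5ccccc5c3C4=O)nn2)O1`, where the change from compound 3 is 2,2-dimethyl-1,3-dioxolan-4-yl in place of 1,2-dihydroxyethyl on a saturated chain carbon bound to an aromatic nitrogen. Put another way, 2,3-dihydroxypropyl becomes (2,2-dimethyl-1,3-dioxolan-4-yl)methyl. Among the compounds with values here, no measured step covers this kind of change, since every measured compound carries free hydroxy groups in this group. Within the data shown here, the only guide is the exchange of one hydroxy-bearing group for another on the aromatic nitrogen, a 1.1-fold higher number from compound 1 to compound 3 (0.05 log units; within the scatter), which is a weak precedent. No shift beyond the scatter is therefore expected in this assay, and no direction is favoured with any confidence, though the range is kept wide. The expected step is a 1.1-fold lower number from compound 3 to compound 4 (0.05 log units; within the scatter). For compound 4 the estimated value is 950 nM, with an expected range of 400 nM to 2200 nM.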

Compound 4, half-maximal inhibitory concentration: 470 nM
The estimate for compound 4 lay 2.0-fold (0.31 log units) above the measured number; the measured number falls inside the stated range.
By their numbers in this assay, from the lowest: compound 4; then compounds 1, 3 and 2 (each within the scatter of the next).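

In this assay, the place on a saturated chain carbon bound to an aromatic nitrogen now shows a step beyond the scatter, which no exchange among the hydroxy-bearing groups had shown: 2,2-dimethyl-1,3-dioxolan-4-yl in place of 1,2-dihydroxyethyl gives a 2.3-fold lower number from compound 3 to compound 4 (0.36 log units; beyond the scatter) and, against the diol with the drawn configuration, a 2.4-fold lower number from compound 2 to compound 4 (0.38 log units; beyond the scatter). The same holds against the larger hydroxy-bearing group, where (2,2-dimethyl-1,3-dioxolan-4-yl)methyl in place of 3,4-dihydroxy-5-(hydroxymethyl)oxolan-2-yl gives a 2.0-fold lower number from compound 1 to compound 4 (0.31 log units; beyond the scatter), so all three steps are modest, point the same way and leave compound 4 with the lowest number of the series. Nothing at hand bears on what lies behind this change in the number.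

Still open, going by these compounds, is whether the step needs the whole five-membered ring of 2,2-dimethyl-1,3-dioxolan-4-yl or would also appear with a simple methyl ether of the diol, and how an amine or a carboxylic acid at this place would read. Also open, on these data alone, is whether the opposite configuration at the defined stereocentre of the 2,2-dimethyl-1,3-dioxolan-4-yl group would give a different number.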